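Methoxy on the aryl ring of a triazole thioether series

The source may hold more compounds than are shown below. What is called first, only, known or untested is meant among the compounds shown, and "the series" means these compounds.

Measured compounds:
Compound 1, `C=CCn1c(SCC(=O)c2ccccc2)nnc1-c1ccccc1`: 70%
Compound 2, `C=CCn1c(SCC(=O)c2ccccc2)nnc1-c1ccc(OC)cc1`: 63%
Compound 3, `O=C(CSc1nnc(-c2ccccc2)n1-c1ccccc1)c1ccccc1`: 64%

All three were tested in a functional assay on the whole organism (strain albino) for inhibition, with Rattus norvegicus as the target, read by paw edema, with a stated time of 3 h, at a dose of 0.28 mmol/kg by the oral route; a higher number here means more inhibition at the dose given (going by the name of the read-out), a lower number less inhibition. Compound 2 differs from compound 1 by methoxy in place of hydrogen on an aromatic carbon, and that change gave a number 7 percentage points lower from compound 1 to compound 2 (within the scatter). Compound 3 differs from compound 1 by phenyl in place of allyl on an aromatic nitrogen, giving a number 6 percentage points lower from compound 1 to compound 3 (within the scatter). Compound 3 and compound 2 lie close together, and neither step from compound 1 is larger than the usual scatter, so no ordering among the three can be claimed.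

Compound 4, `COc1ccc(-c2nnc(SCC(=O)c3ccccc3)n2-c2ccccc2)cc1`, has not yet been measured. It differs from compound 3 by methoxy in place of hydrogen on an aromatic carbon, the same change, made at the same place, that turned compound 1 into compound 2. For the measured compounds named here, on the core of compound 3 the step is expected to be about a number 6 percentage points lower from compound 3 to compound 4 (within the scatter), resting on the single earlier example, compound 1 to compound 2, where the step was a number 7 percentage points lower from compound 1 to compound 2 (within the scatter). Compound 4 is therefore estimated at 58%, with a likely range from 47% to 68%.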

Compound 4, a percentage reported as inhibition, in the whole organism at one dose (the size of the read-out at that dose, not a potency): 58%
The estimate for compound 4 equals the measured number at the digits printed; low and high end bracket the measured number.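

In this assay, methoxy in place of hydrogen on an aromatic carbon gave a number 6 percentage points lower from compound 3 to compound 4 (within the scatter), and this step can be set beside the same change on the core carrying allyl: the same change on two cores in this assay, a number 7 percentage points lower (within the scatter) from compound 1 to compound 2 and a number 6 percentage points lower (within the scatter) from compound 3 to compound 4, 1 percentage points apart, within the scatter of two such steps. Phenyl in place of allyl on an aromatic nitrogen gave a number 5 percentage points lower from compound 2 to compound 4 (within the scatter), and this too can be set beside its earlier example: the same change on two cores in this assay, a number 6 percentage points lower (within the scatter) from compound 1 to compound 3 and a number 5 percentage points lower (within the scatter) from compound 2 to compound 4, 1 percentage points apart, within the scatter of two such steps. Each change therefore behaved alike on the two cores shown, but every one of these steps lies within the scatter, so the agreement does not show that either change really alters inhibition, and two cores at a single dose cannot establish a general rule for the series.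

The compounds shown leave open whether a different group at the same place on the aromatic ring, such as an amine or a carboxylic acid, would give a step beyond the scatter. They also leave open what a longer chain on the aromatic nitrogen would do.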